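This account rests on a few compounds, and the source may have more. Where it says the series, first, only, none or still open, it means among the compounds named here.

Measured compounds in the series:
compound 1 `Cc1ccccc1-n1cc(-c2ccccc2NS(=O)(=O)c2c[nH]c(=O)[nH]c2=O)nn1`, 56600 nM
compound 2 `O=c1[nH]cc(S(=O)(=O)Nc2cccc(-c3cn(-c4ccccc4Cl)nn3)c2)c(=O)[nH]1`, 11500 nM
compound 3 `O=c1[nH]cc(S(=O)(=O)Nc2ccc(-c3cn(-c4ccccc4)nn3)cc2)c(=O)[nH]1`, "not toxic" (no number reported)

In an ADME assay on L02 cells (Homo sapiens) for cytotoxicity, read by MTT assay, with a stated time of 24 h (a lower number here means that less compound is tolerated, a higher number that more compound is tolerated), compound 1 gives 56600 nM and compound 2 gives 11500 nM; compound 3 was recorded as "not toxic" (no number reported), with no concentration given, so it has no place on the numeric scale. Compound 4 `O=c1[nH]cc(S(=O)(=O)Nc2ccc(-c3cn(-c4cccc(F)c4)nn3)cc2)c(=O)[nH]1` has not been measured in this assay. It differs from compound 3 by fluoro in place of hydrogen on an aromatic carbon, phenyl to 3-fluorophenyl. Among the compounds with values here, no step between measured pairs is available to gauge such a change; the expectation is a shift no larger than the usual scatter, in no set direction, with compound 4 staying weakly toxic at best. Compound 4 is estimated to give about 50000 nM in this assay, within a range of 15000 nM to 150000 nM.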

Compound 4, half-maximal cytotoxic concentration: "not toxic" (no number reported)
Compound 4 has no reported number here, so the estimate cannot be set against anything.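

Compound 3 and compound 4 are both recorded as not toxic, without a number, so no step can be read between them, and no evidence bears on this result. Going by these compounds, whether phenyl to 3-fluorophenyl shifts tolerance at all stays open.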